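A few compounds are considered here, and "the series" means these few. Any claim that something is new, unique, unknown or untested is made for them only; others in the source may bear on it.

Working notes on a short series tested for cytotoxicity. Three compounds share one core: compound 1 `C=Cc1cccc(C(=O)N2CCCC(C(=O)Nc3ccc(Cl)cc3)C2)c1`, compound 2 `C=CCOc1cccc(NC(=O)C2CCCN(C(=O)c3cc(C(F)(F)F)cc(C(F)(F)F)c3)C2)c1` and compound 3 `O=C(Nc1ccc(Cl)cc1)C1CCCN(C(=O)c2ccc(-c3ccco3)cc2)C1`. In an ADME assay on PC-3 cells (Homo sapiens) for cytotoxicity, read by WST assay, tested at 100 uM (a higher number here means more inhibition at the concentration tested (going by the name of the read-out), a lower number less inhibition), compound 1 gives 0%, compound 2 gives 0% and compound 3 gives 6%. Compound 2 stands level with compound 1 at the digits shown, and the reading of compound 3 lies within the usual scatter of that of compound 2, so the three numbers give no spread to speak of; none of them rises clearly off the floor of the read-out.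

Compound 4 `CC(C)(C)OC(=O)c1cccc(NC(=O)C2CCCN(C(=O)c3cc(C(F)(F)F)cc(C(F)(F)F)c3)C2)c1` is not yet measured. It differs from compound 2 in one place: tert-butoxycarbonyl in place of allyloxy on an aromatic carbon. For the measured compounds named here, no pair of measured compounds shows a step of this kind, so there is no measured step to lean on. With every measured compound sitting at or near the floor in this assay, the expectation for compound 4 is no step beyond the scatter, a number 3 percentage points higher from compound 2 to compound 4 (within the scatter), and compound 4 is estimated at 3%, in the range 0% to 15%.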

Compound 4, a percentage reported as inhibition, at one concentration (the size of the read-out at that concentration, not a potency): 0%
Estimate against measurement, compound 4: 3 percentage points above, and the stated range covers the measured number.
By their numbers in this assay, from the lowest: compounds 1, 2, 4 and 3 (each within the scatter of the next).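

For the compounds shown here, this is the first step read at this position: in this assay, tert-butoxycarbonyl in place of allyloxy on an aromatic carbon, meta to a large group, gives no change at the digits printed from compound 2 to compound 4 (within the scatter). The entering group is the larger by heavy-atom count and carries the extra oxygen, yet the reading stays at the floor of the read-out, so the floor reading of compound 2 is not particular to allyloxy. Nothing measured here speaks to why the reading stays flat.

As far as these compounds go, whether a group of another kind on that aromatic carbon, such as an amine or a carboxylic acid, would lift the number clear of the scatter stays open. A step read at the floor also cannot tell how this position would behave in a compound with a clearly higher reading.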